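The source may hold more compounds than are shown below. What is called first, only, known or untested is meant among the compounds shown, and "the series" means these compounds.

Compound 1 `Cc1nc(S(C)(=O)=O)ccc1Oc1ncnc(OC2CCN(C(=O)OC(C)F)CC2)c1F` gives 65.5 nM in a functional assay on isolated protein for inhibition of Glucose-dependent insulinotropic receptor (Homo sapiens), read by HTRF and cAMP accumulation; a lower number here means that less compound is needed, a higher number that more compound is needed for the effect. Compound 2 `Cc1nc(S(C)(=O)=O)ccc1Oc1ncnc(OC2CCN(C(=S)OC(C)C)CC2)c1F` gives 69.9 nM, a step of a 1.1-fold higher number from compound 1 to compound 2 (0.03 log units; within the scatter); compound 2 thus has the higher of the two numbers, but only by a margin that the assay cannot resolve. Compound 3 `Cc1nc(S(C)(=O)=O)ccc1Oc1ncnc(OC2CCN(C(=O)c3noc(C(C)C)n3)CC2)c1F` differs from compound 2 by a group of 10 heavy atoms (6 carbon, 2 nitrogen, 2 oxygen; one five-membered aromatic ring with 3 hetero atoms) in place of a group of 6 heavy atoms (4 carbon, 1 oxygen, 1 sulfur; no ring), on an amine nitrogen in a ring. No measured step mirrors this change; the only step shown, from compound 1 to compound 2, was within the scatter and replaced one small acyclic group with another on that same nitrogen. Compound 3 is therefore expected to land near compound 2, at an estimated 80 nM with a range from 30 nM to 250 nM, a step of a 1.1-fold higher number from compound 2 to compound 3 (0.06 log units; within the scatter).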

Compound 3, half-maximal effective concentration: 21.2 nM
Beside the measured number, compound 3's estimate is 3.8-fold (0.58 log units) above it, and the stated range ends above it.
By their numbers in this assay, from the lowest: compound 3; then compounds 1 and 2 (each within the scatter of the next).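

On the amine nitrogen in a ring, the earlier pair compared only small groups with no ring. Replacing such a group with one carrying a five-membered aromatic ring with 3 hetero atoms gives a clear change in this assay, with a 3.3-fold lower number from compound 2 to compound 3 (0.52 log units; beyond the scatter) and a 3.1-fold lower number from compound 1 to compound 3 (0.49 log units; beyond the scatter), so this position responds to the group placed on it. Nothing measured here explains this change. Going by these compounds, it remains open whether the aromatic ring itself matters, and how a phenyl ring would compare in its place.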